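Oxazoline to thiazoline on the sulfonylmethyl arm of compound 1

A few compounds are considered here, and "the series" means these few. Any claim that something is new, unique, unknown or untested is made for them only; others in the source may bear on it.

Compound 1 `O=S(=O)(CC1=NCCO1)c1c(-c2ccc(Cl)cc2)nn(-c2ccccc2)c1-c1ccc(Cl)cc1` carries an oxazoline on the carbon bound to the sulfonyl sulfur. In a functional assay, read by Griess assay, with a stated time of 150 min, tested at 50 ug/mL (a higher number here means a stronger effect of the compound at the concentration tested, a lower number a weaker effect), compound 1 gives "not active" (no number reported), so no number stands for it and no order against the other entries can be drawn. Compound 2 `COc1ccc(C2=NN(c3ccccc3)C(c3ccc(C)cc3)C2S(=O)(=O)CC2=NCCO2)cc1`, which shares the oxazoline arm on a different saturated core, gives 59.1% in this assay. Within the data shown here, compound 3 `Cc1ccc(-c2c[nH]nc2S(=O)(=O)CC2=NCCS2)cc1`, the only thiazoline example measured, gives "not active" (no number reported) in this assay, again without a number. Compound 4 `O=S(=O)(CC1=NCCS1)c1c(-c2ccc(Cl)cc2)nn(-c2ccccc2)c1-c1ccc(Cl)cc1` is the counterpart of compound 1 with the change (a group of 5 heavy atoms (3 carbon, 1 nitrogen, 1 sulfur; one five-membered non-aromatic ring with 2 hetero atoms) in place of a group of 5 heavy atoms (3 carbon, 1 nitrogen, 1 oxygen; one five-membered non-aromatic ring with 2 hetero atoms), on a saturated chain carbon bound to a sulfonyl sulfur). Among the measured compounds shown here, no measured pair shows this exchange on a shared core, so no size can be read for it; the expectation is a step of no size beyond the scatter, and a reading at the low end of the scale, since compound 1 gives "not active" (no number reported) and compound 3 gives "not active" (no number reported). Compound 4 is therefore expected to give about 12% in this assay, within 0% to 35%, with a fair chance that it is again reported without a number.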

Compound 4, a percentage reported as activity, at one concentration (the size of the read-out at that concentration, not a potency): "not active" (no number reported)
Compound 4 has no reported number here; the estimate stays without a comparison.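

In this assay compound 1 gives "not active" (no number reported) and compound 4 gives "not active" (no number reported) and so no step can be read between them. The compounds shown leave open what the oxazoline to thiazoline exchange does on a core with a numerical read-out. No supporting data bear on this result.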